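From Compound 1 to Compound 3 in the Antiproliferative Series

This account rests on a few compounds, and the source may have more. Where it says the series, first, only, none or still open, it means among the compounds named here.

compound 1 `COc1ccc(/C=C/c2nnc(-c3ccc4c(c3)OCCO4)o2)cc1` — > 50000 nM
compound 2 `O=[N+]([O-])c1ccc(/C=C/c2nnc(-c3ccc4c(c3)OCCO4)o2)cc1` — 32100 nM

In a functional assay on HUVEC cells (Homo sapiens) for antiproliferative activity, read by MTT assay, with a stated time of 48 h (a higher number here means a weaker inhibitor, a lower number a stronger inhibitor), compound 1 gives > 50000 nM, which is a limit of the assay and not a number. Compound 2 gives 32100 nM in this assay. For the measured compounds named here, the only measured step is an at least 1.5-fold lower number from compound 1 to compound 2 (0.19 log units; that floor lies within the scatter), a change to a different group; its floor lies within the scatter, and compound 1 sits at the limit of > 50000 nM in this assay, at which 1 of the 2 values shown sits. Compound 3 `Cc1ccccc1/C=C/c1nnc(-c2ccc3c(c2)OCCO3)o1` differs from compound 1 by 2-methylphenyl in place of 4-methoxyphenyl on a double-bonded chain carbon bound to a double-bonded chain carbon. Going by the values given here, no measured step covers this change, so compound 3 is expected to stay near compound 1, and a number no higher from compound 1 to compound 3 (the limit leaves the size open) is expected to lie within the scatter. Compound 3 is estimated at 50000 nM, between 20000 nM and 150000 nM.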

Compound 3, half-maximal inhibitory concentration: 40500 nM
Compound 3: middle estimate off by 1.2-fold (0.09 log units), on the high side; the measured number falls inside the stated range.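

The change to 2-methylphenyl, which carries no hydrogen-bond acceptor where 4-methoxyphenyl carries one, gives an at least 1.2-fold lower number from compound 1 to compound 3 (0.09 log units; that floor lies within the scatter) in this assay. Removing that acceptor therefore does not raise the number here, though the step shows no gain beyond the scatter. The value of compound 1 is a limit, so the full size of this step cannot be read: the limit of > 50000 nM in this assay, at which 1 of the 3 values shown sits.

On these data alone, whether 4-methylphenyl would read like 2-methylphenyl stays open. So does whether an amine or a carboxylic acid on this phenyl ring would bring the number down clearly.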